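Removing One Methoxy Group from the Strongest Compound

A few compounds are considered here, and "the series" means these few. Any claim that something is new, unique, unknown or untested is made for them only; others in the source may bear on it.

So far, three compounds sharing one core have been tested in a functional assay on U-87MG ATCC cells for antiproliferative activity against U-87 MG (Homo sapiens), read by MTT assay, with a stated time of 48 h, tested at 50 uM; on this read-out lower numbers stand for a stronger effect and higher numbers for a weaker effect at the one concentration tested. Compound 1 `COc1ccc(-c2nc(SCC(=O)c3sc(-c4ccccc4)nc3C)[nH]c(=O)c2C#N)cc1` gives 52.1%. Compound 2 `Cc1nc(-c2ccccc2)sc1C(=O)CSc1nc(-c2ccccc2)c(C#N)c(=O)[nH]1` gives 77.5%. Compound 3 `COc1ccc(-c2nc(SCC(=O)c3sc(-c4ccccc4)nc3C)[nH]c(=O)c2C#N)cc1OC` gives 21.4%, the lowest of the three numbers and therefore the strongest effect seen so far; its two companions both lie beyond the scatter above it.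

The next compound, compound 4 `COc1cccc(-c2nc(SCC(=O)c3sc(-c4ccccc4)nc3C)[nH]c(=O)c2C#N)c1`, differs from compound 3 in one place: hydrogen in place of methoxy on an aromatic carbon.

Two measured steps speak to this change, both involving a methoxy group on the same aromatic ring. The step of a number 30.7 percentage points lower from compound 1 to compound 3 (beyond the scatter) shows that adding a methoxy group brought a large drop in the number, while a number 25.4 percentage points higher from compound 1 to compound 2 (beyond the scatter) shows that taking one away raised it. The larger comparison a number 56.1 percentage points lower from compound 2 to compound 3 (beyond the scatter) points the same way. Compound 4 keeps one of the two methoxy groups, so the number is expected to rise from compound 3, though probably not all the way to compound 2.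

The step expected is a number 23.6 percentage points higher from compound 3 to compound 4 (beyond the scatter), a rise well beyond the scatter. Compound 4 is therefore estimated at 45%, with a range from 25% to 68%.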

Compound 4, a percentage reported as activity, at one concentration (the size of the read-out at that concentration, not a potency): 80.3%
Compound 4: middle estimate off by 35.3 percentage points, on the low side, outside the stated range (above it).
By their numbers in this assay, from the lowest: compound 3; then compound 1; then compounds 2 and 4 (each within the scatter of the next).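

In this assay, the methoxy para to a large group matters far more when a second methoxy sits ortho to it, with a number 58.9 percentage points higher from compound 3 to compound 4 (beyond the scatter), so the same removal does not carry a fixed cost across the shared core: the same change on two cores in this assay, a number 25.4 percentage points higher (beyond the scatter) from compound 1 to compound 2 and a number 58.9 percentage points higher (beyond the scatter) from compound 3 to compound 4, 33.5 percentage points apart, beyond the scatter of two such steps The other methoxy depends just as much on its surroundings, since without the para methoxy it gives a number 2.8 percentage points higher from compound 2 to compound 4 (within the scatter), which leaves 3-methoxyphenyl and phenyl indistinguishable here, while adding it to 4-methoxyphenyl gave a clear drop: the same change on two cores in this assay, a number 30.7 percentage points lower (beyond the scatter) from compound 1 to compound 3 and a number 2.8 percentage points higher (within the scatter) from compound 2 to compound 4, 33.5 percentage points apart, beyond the scatter of two such steps A single methoxy is also not interchangeable between the two places, as a number 28.2 percentage points higher from compound 1 to compound 4 (beyond the scatter) shows, and among these four compounds the lowest number comes only with both groups together on the ring.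

Why the two methoxy groups work better as a pair than their separate steps would suggest remains unexplained by these numbers, which come from one concentration in one cell line. On these data alone, it also remains open whether a hydroxy group, a fluorine atom or a longer ethoxy chain at the para place could stand in for methoxy alongside the 3-methoxy group.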